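Carbamate aryl variation in a cellular inhibition series

A few compounds are considered here, and "the series" means these few. Any claim that something is new, unique, unknown or untested is made for them only; others in the source may bear on it.

Measured so far:
compound 1 `CC(C)=CCC1Cc2c(OCCCNC(=O)c3cccs3)cc(=O)n(CCCO)c2CC1(C)C` — 5.6%
compound 2 `CC(C)=CCC1Cc2c(OC(=O)Nc3cccc(F)c3)cc(=O)n(CCCO)c2CC1(C)C` — 0%

In a functional assay on PANC-1 cells (Homo sapiens) for inhibition, read by MTT assay, with a stated time of 24 h, tested at 10 uM (a higher number here means more inhibition at the concentration tested (going by the name of the read-out), a lower number less inhibition), compound 2 gives 0%, the lowest of the two numbers; its nearest neighbour is compound 1, which in this assay gives 5.6%, and the step of a number 5.6 percentage points lower from compound 1 to compound 2 (within the scatter) lies within the scatter. Compound 3 `CC(C)=CCC1Cc2c(OC(=O)Nc3ccc(F)cc3F)cc(=O)n(CCCO)c2CC1(C)C` differs from compound 2 by 2,4-difluorophenyl in place of 3-fluorophenyl on an amide-type nitrogen. Going by the values given here, no measured step alters the aryl on the carbamoyl nitrogen; the one step on record, a number 5.6 percentage points lower from compound 1 to compound 2 (within the scatter), exchanged the whole side chain on the aromatic oxygen and still stayed within the scatter, so it offers no ground for a shift beyond the scatter in this assay. Compound 3 is therefore expected to give about 3%, within 0% to 14%. The expected step of a number 3 percentage points higher from compound 2 to compound 3 (within the scatter) is thus estimated to remain within the scatter.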

Compound 3, a percentage reported as inhibition, at one concentration (the size of the read-out at that concentration, not a potency): 0%
Beside the measured number, compound 3's estimate is 3 percentage points above it; the range from low to high includes it.
By their numbers in this assay, from the lowest: compounds 2, 3 and 1 (each within the scatter of the next).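

In this assay, the aryl on the amide-type nitrogen now has a step that can be read: 2,4-difluorophenyl in place of 3-fluorophenyl gives no change at the digits printed from compound 2 to compound 3 (within the scatter), so the two fluorinated carbamates cannot be told apart here. The exchange on the oxygen on an aromatic ring reads the same way with this second aryl, with a number 5.6 percentage points lower from compound 1 to compound 3 (within the scatter), so neither carbamate separates from the thiophene amide side chain of compound 1. No accompanying measurement bears on this result.

Going by these compounds, all three compounds lie within the scatter of one another, so it remains open whether any group on this carbamate can raise inhibition beyond the scatter. A phenyl ring carrying an amine or a carboxylic acid, or a longer chain between the amide-type nitrogen and the ring, would test this position further.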